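Swapping a substituted pyridine for a dimethylpyrazole on a fused core

The source may report more compounds than this note shows. Statements on the series, on what has been measured and on what is new or still open speak of the compounds shown alone.

The series compares two measured compounds in a physicochemical assay for solubility, read by LC-MS, in phosphate buffer, with a stated time of 24 h, at pH 7.4; a lower number here means a less soluble compound, a higher number a more soluble compound. Compound 1, with structure `Cc1nc(CO)ccc1-c1cnc(NCc2c(F)ccc3c2CCO3)c2cn[nH]c(=O)c12`, gives 3000 nM in this assay, and this is the lowest of the two numbers. Compound 2, with structure `CN(c1ccn(C)n1)c1cnc(NCc2c(F)ccc3c2CCO3)n2cnnc12`, gives 130000 nM in this assay, a value that stands well above that of compound 1. Compound 2 is built on a different core, so nothing beyond these two numbers can be drawn from the pair.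

The next compound follows from compound 1 alone. Compound 3, with structure `Cc1nn(C)cc1-c1cnc(NCc2c(F)ccc3c2CCO3)c2cn[nH]c(=O)c12`, differs from compound 1 in one place: 1,3-dimethyl-1H-pyrazol-4-yl in place of 6-(hydroxymethyl)-2-methylpyridin-3-yl on an aromatic carbon. No measured pair in this set shares that change, so its effect on solubility is not known from the data shown. The expectation is a small step, if any, that may not exceed the usual scatter, and the direction is uncertain. For compound 3 the estimated solubility in this assay is 2500 nM, within a range from 600 nM to 10000 nM, which would mean a step of a 1.2-fold lower number from compound 1 to compound 3 (0.08 log units; within the scatter).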

Compound 3, solubility: 9000 nM
Beside the measured number, compound 3's estimate is 3.6-fold (0.56 log units) below it, within the range that was stated.
By their numbers in this assay, from the lowest: compound 1; then compound 3; then compound 2.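

In this assay, among the compounds shown here, putting 1,3-dimethyl-1H-pyrazol-4-yl in place of 6-(hydroxymethyl)-2-methylpyridin-3-yl gives a 3.0-fold higher number from compound 1 to compound 3 (0.48 log units; beyond the scatter), the first single-place step in this set. It shows that the number can move upward at this aromatic carbon on the core of compound 1, even as a five-membered aromatic ring replaces a six-membered one and the hydrogen-bond donor of the leaving group is lost. Nothing in the data accounts for the size or direction of this step.

The change alters the ring, the hydroxymethyl group and the methyl groups all at once, so the compounds shown do not separate which of these parts goes with the step. On these data alone, it also remains open whether a pyrazole carrying a hydroxymethyl group, or a morpholine or another amine on this aromatic carbon, would give a number above or below that of compound 3, and whether the same exchange would give a similar step on the core of compound 2.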